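The source may report more compounds than this note shows. Statements on the series, on what has been measured and on what is new or still open speak of the compounds shown alone.

Series notes. Compound 1 `CN(C)CCn1cnnc1-c1cc(Oc2ccc(NC(=O)N/N=C/c3ccc(O)cc3)cc2F)ccn1`, compound 2 `CN(C)CCn1cnnc1-c1cc(Oc2ccc(NC(=O)N/N=C/c3cc(Br)c(O)c(Br)c3)cc2F)ccn1` and compound 3 `COc1cc(/C=N/NC(=O)Nc2ccc(Oc3ccnc(-c4nncn4CCN(C)C)c3)c(F)c2)cc(OC)c1OC` share one core and differ only in the aryl group on a carbon with a double bond to nitrogen. In a functional assay on NCI-H460 cells (Homo sapiens) for cytotoxicity, read by MTT assay, with a stated time of 72 h (a higher number here means a weaker inhibitor, a lower number a stronger inhibitor), compound 1 gives 1780 nM, compound 2 gives 3760 nM and compound 3 gives 2770 nM. Compound 3 stands second highest of the three numbers: its nearest neighbour is compound 2, a 1.4-fold lower number from compound 2 to compound 3 (0.13 log units; within the scatter), and its furthest is compound 1, a 1.6-fold higher number from compound 1 to compound 3 (0.19 log units; within the scatter). Going by the values given here, the only step beyond the scatter is a 2.1-fold higher number from compound 1 to compound 2 (0.32 log units; beyond the scatter), a modest one.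

Compound 4 `CN(C)CCn1cnnc1-c1cc(Oc2ccc(NC(=O)N/N=C/c3ccc(Cl)cc3Cl)cc2F)ccn1` is not yet measured. 2,4-dichlorophenyl in place of 3,4,5-trimethoxyphenyl on a carbon with a double bond to nitrogen

Among the compounds with values here, the steps that bear on this change are the aryl swaps already seen: a 1.6-fold higher number from compound 1 to compound 3 (0.19 log units; within the scatter) and a 1.4-fold lower number from compound 2 to compound 3 (0.13 log units; within the scatter), both within the scatter, and a 2.1-fold higher number from compound 1 to compound 2 (0.32 log units; beyond the scatter), in which halogens entered. Since 2,4-dichlorophenyl now enters, only a small shift toward a higher number, if any, is expected in this assay. For compound 4 the estimated step is a 1.2-fold higher number from compound 3 to compound 4 (0.06 log units; within the scatter). For compound 4 the expected value is 3200 nM, with a range from 1500 nM to 7000 nM.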

Compound 4, half-maximal inhibitory concentration: 130 nM
Compound 4: the middle estimate sits 25-fold (1.39 log units) above what was measured, and the stated range ends above it.
By their numbers in this assay, from the lowest: compound 4; then compounds 1, 3 and 2 (each within the scatter of the next, the first and the last beyond it).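

In this assay, going by these compounds alone, the aryl group on a carbon with a double bond to nitrogen proves far more responsive than the earlier compounds showed: with 2,4-dichlorophenyl there is a 21-fold lower number from compound 3 to compound 4 (1.33 log units; beyond the scatter) and also a 29-fold lower number from compound 2 to compound 4 (1.46 log units; beyond the scatter) and a 14-fold lower number from compound 1 to compound 4 (1.14 log units; beyond the scatter) in this series, all large. Halogen on the aryl group is not enough by itself, since compound 2 carries bromine in its 3,5-dibromo-4-hydroxyphenyl group and does not share this low number; compound 4 alone has an aryl group without oxygen, so the absence of oxygen and the presence of chlorine cannot be separated here. Nothing available explains the result.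

Whether both chlorines are needed remains open, as no phenyl group with a single chlorine is shown. Nor is it shown whether methyl groups in place of the chlorines would give a similarly low number.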